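Compound 3 to compound 4: chloro in place of fluoro

This account rests on a few compounds, and the source may have more. Where it says the series, first, only, none or still open, it means among the compounds named here.

compound 1 `CN1C/C(=C\c2ccc(C#N)cc2)C(=O)/C(=C/c2ccccc2F)C1` gives 590 nM
compound 2 `CN1C/C(=C\c2ccc(Cl)cc2)C(=O)/C(=C/c2cccc([N+](=O)[O-])c2)C1` gives 8210 nM
compound 3 `CN1C/C(=C\c2ccc(F)cc2)C(=O)/C(=C/c2ccc(C#N)cc2)C1` gives 6140 nM

In a functional assay on HepG2 cells (Homo sapiens) for cytotoxicity, read by MTT assay, with a stated time of 24 h (a lower number here means a stronger inhibitor, a higher number a weaker inhibitor), compound 3 gives 6140 nM as its value, within the scatter of compound 2 at 8210 nM as measured. For the measured compounds named here, compound 1 stands apart from it, and the only measured step in one place is a 10-fold higher number from compound 1 to compound 3 (1.02 log units; beyond the scatter). That step is 4-fluorophenyl in place of 2-fluorophenyl, so it moves the halogen and does not exchange it.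

Compound 4 `CN1C/C(=C\c2ccc(Cl)cc2)C(=O)/C(=C/c2ccc(C#N)cc2)C1` differs from compound 3 by chloro in place of fluoro on an aromatic carbon and the change is chloro in place of fluoro on an aromatic carbon, para to a large group. Going by the values given here, no measured pair isolates this exchange. The closest evidence is compound 2, which carries 4-chlorophenyl with a different second aryl group and gives 8210 nM in this assay, a value within the scatter of the value for compound 3.

No change beyond the scatter is therefore expected, in either direction, and the estimated step is a 1.0-fold lower number from compound 3 to compound 4 (0.01 log units; within the scatter). The large step on the fluorophenyl group still argues for a wide range. Compound 4 is expected at 6000 nM, with an estimated range from 2500 nM to 14000 nM.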

Compound 4, half-maximal inhibitory concentration: 5950 nM
The estimate for compound 4 lay 1.0-fold (0.00 log units) above the measured number, within the range that was stated.
By their numbers in this assay, from the lowest: compound 1; then compounds 4, 3 and 2 (each within the scatter of the next).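

In this assay, fluoro and chloro on this aromatic carbon, para to a large group, cannot be told apart: the direct exchange gives a 1.0-fold lower number from compound 3 to compound 4 (0.01 log units; within the scatter). Compound 2 could not offer this comparison. It also differs in its second aryl group. The gap to compound 1 survives the exchange, with a 10-fold higher number from compound 1 to compound 4 (1.00 log units; beyond the scatter) alongside a 10-fold higher number from compound 1 to compound 3 (1.02 log units; beyond the scatter), so among these compounds the 2-fluorophenyl arrangement of compound 1 stands apart from both the 4-fluorophenyl of compound 3 and the 4-chlorophenyl of compound 4. Nothing available for this series accounts for either the flat exchange or the large gap to compound 1.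

The compounds shown leave open whether a methoxy group or an amine on this aromatic carbon would also stay within the scatter of compound 3 and compound 4, or whether the tolerance seen here is confined to the two halogens. They also leave open whether a 2-chlorophenyl group would match the 2-fluorophenyl group of compound 1, and whether the exchange of fluoro for chloro stays within the scatter when the other aryl group carries something other than the nitrile.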